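From acetyl to propanoyl on compound 3

The compounds below may be only part of what the source reports. "The series", "measured", "known", "first", "only" and "open" are said of these compounds alone.

Going by the values given here, in a functional assay on HCT-116 cells (Homo sapiens) for antiproliferative activity, read by MTT assay, with a stated time of 72 h (a lower number here means a stronger inhibitor, a higher number a weaker inhibitor), compound 3 (`CC(=O)NNC(=O)c1csc2ncc(-c3ccc(C)cc3)n12`) reads 71800 nM and sits at the weak end of the three compounds measured so far. Compound 1 (`CCOC(=O)c1csc2nc(CN3CCN(Cc4ccccc4)CC3)c(-c3ccc(Br)cc3)n12`) gives 37200 nM and lies within the usual scatter of compound 3, so that pair cannot be ranked. Compound 2 (`Cc1ccc(-c2c(CN3CCCCC3)nc3scc(C(=O)O)n23)cc1`) gives 13800 nM as a lower number beyond the scatter, which makes it the stronger inhibitor of the two.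

Compound 4 (`CCC(=O)NNC(=O)c1csc2ncc(-c3ccc(C)cc3)n12`) is compound 3 with a single change (methyl in place of hydrogen on a saturated chain carbon bound to a carbonyl carbon). It carries methyl in place of hydrogen on a saturated chain carbon bound to a carbonyl carbon, which turns acetyl into propanoyl.

Among the compounds with values here, no two measured compounds differ in one place only, so the data give no direct guide to the size of such a step. Compound 1 and compound 2 both differ from compound 3 in several places at once. Within the data shown here, the only close neighbour is therefore compound 3 at 71800 nM and no step beyond the scatter is expected in this assay in either direction. An estimated step of a 1.1-fold lower number from compound 3 to compound 4 (0.04 log units; within the scatter) of this size would stay within the scatter. The estimated value for compound 4 is 65000 nM (30000 nM to 130000 nM).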

Compound 4, half-maximal inhibitory concentration: 9230 nM
The estimate for compound 4 lay 7.0-fold (0.85 log units) above the measured number, and the stated range ends above it.
By their numbers in this assay, from the lowest: compounds 4 and 2 (each within the scatter of the next); then compounds 1 and 3 (each within the scatter of the next).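

In this assay, going by these compounds alone, placing a methyl in place of hydrogen on a saturated chain carbon bound to a carbonyl carbon turns acetyl into propanoyl and gives a 7.8-fold lower number from compound 3 to compound 4 (0.89 log units; beyond the scatter), the only step here between compounds that differ in one place. Within the data shown here, this shows that the read-out at this position can respond to a change of just 1 heavy atom, which the earlier compounds could not show, as they differ from one another in several places at once. No independent data bear on the result, so the size of this step remains unexplained.

As far as these compounds go, a single step sets no trend, so it remains open whether a butanoyl group, with its longer chain, would extend the change, leave it unchanged or reverse it, and the same question applies to an amine on that saturated chain carbon. Also open, from the compounds shown here alone, is whether the same change from acetyl to propanoyl would give a step of similar size on a different core, such as the core of compound 1 or the core of compound 2.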